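Halogen swap on the hydrazone carbon: predicting compound 4

This account rests on a few compounds, and the source may have more. Where it says the series, first, only, none or still open, it means among the compounds named here.

The measured compounds:
compound 1, `CN(C)CCn1cnnc1-c1cc(Oc2ccc(NC(=O)N/N=C/c3cccc(Cl)c3Cl)cc2F)ccn1`; in a functional assay on A549 cells (Homo sapiens) for cytotoxicity, read by MTT assay, with a stated time of 72 h (on this read-out higher numbers stand for weaker inhibition and lower numbers for stronger inhibition), compound 1 gives 1090 nM
compound 2, `COc1ccc(/C=N/NC(=O)Nc2ccc(Oc3ccnc(-c4nncn4CCN(C)C)c3)c(F)c2)cc1O`; in this assay compound 2 gives only a limit, > 100000 nM
compound 3, `CN(C)CCn1cnnc1-c1cc(Oc2ccc(NC(=O)N/N=C/c3ccc(F)cc3F)cc2F)ccn1`; in this assay compound 3 gives 1870 nM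

Of the three results, two are numbers and one is a limit. Compound 3 and compound 1 sit within the scatter of each other, the step being a 1.7-fold higher number from compound 1 to compound 3 (0.23 log units; within the scatter). Compound 2 sits at the limit, (the limit of > 100000 nM in this assay, at which 1 of the 3 values shown sits).

Compound 4, `CN(C)CCn1cnnc1-c1cc(Oc2ccc(NC(=O)N/N=C/c3ccc(Cl)cc3Cl)cc2F)ccn1`, differs from compound 3 in one place: 2,4-dichlorophenyl in place of 2,4-difluorophenyl on a carbon with a double bond to nitrogen. Two kinds of step bear on it. Exchanging one dihalogenated phenyl for another gave a 1.7-fold higher number from compound 1 to compound 3 (0.23 log units; within the scatter), a change inside the scatter. Exchanging a halogenated phenyl for 3-hydroxy-4-methoxyphenyl gave an at least 91-fold higher number from compound 1 to compound 2 (1.96 log units; beyond the scatter), and the reverse gave an at least 53-fold lower number from compound 2 to compound 3 (1.72 log units; beyond the scatter). The move to compound 4 is of the first kind, so compound 4 is expected to show no step beyond the scatter, a 1.4-fold lower number from compound 3 to compound 4 (0.16 log units; within the scatter). The estimate for compound 4 in this assay is 1300 nM, with a range from 500 nM to 3500 nM.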

Compound 4, half-maximal inhibitory concentration: 810 nM
For compound 4 the middle estimate is 1.6-fold (0.21 log units) above the measured one, within the range that was stated.
By their numbers in this assay, from the lowest: compounds 4, 1 and 3 (each within the scatter of the next, the first and the last beyond it). At a limit, above all of these: compound 2.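

In this assay, among these compounds, exchanging only the halogen, 2,4-dichlorophenyl in place of 2,4-difluorophenyl, gives a 2.3-fold lower number from compound 3 to compound 4 (0.36 log units; beyond the scatter), the first step between two dihalogenated phenyl groups at this carbon to lie beyond the scatter, though it is modest; changing only where the two chlorines sit, 2,4-dichlorophenyl in place of 2,3-dichlorophenyl, gives a 1.3-fold lower number from compound 1 to compound 4 (0.13 log units; within the scatter), which lies within it. The gap to the non-halogenated group widens with this compound, at an at least 120-fold lower number from compound 2 to compound 4 (2.09 log units; beyond the scatter), but that step is a bound and not an exact size. Compound 2 remains a limit and not a number: the limit of > 100000 nM in this assay, at which 1 of the 4 values shown sits.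

The compounds shown leave open how an unsubstituted phenyl, or a phenyl carrying an amine or a carboxylic acid, would read at this carbon. They also leave open whether the hydroxy or the methoxy group accounts for the result of compound 2.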